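Trifluoromethoxy for trifluoromethyl on the aryl substituent

This account rests on a few compounds, and the source may have more. Where it says the series, first, only, none or still open, it means among the compounds named here.

Working notes on a small series tested in an assay on isolated protein for inhibition of DNA topoisomerase 1 (Homo sapiens), with a stated time of 30 min, tested at 20 uM; on this read-out lower numbers stand for a weaker effect and higher numbers for a stronger effect at the one concentration tested. Compound 1 `Cc1ccc2c(=O)[nH]c(-c3ccccc3F)nc2c1` gives 0%. Compound 2 `Cc1ccc2nc(-c3cccc(C(F)(F)F)c3)[nH]c(=O)c2c1` gives 4.2%. Compound 2 has the higher of the two recorded numbers, yet its distance to compound 1 lies within the scatter, so the two values cannot be told apart and both sit near the floor of the read-out. For the measured compounds named here, no step between measured compounds is available for comparison. Compound 3 `Cc1ccc2nc(-c3cccc(OC(F)(F)F)c3)[nH]c(=O)c2c1` remains unmeasured. It differs from compound 2 as follows: trifluoromethoxy in place of trifluoromethyl on an aromatic carbon. Since compound 2 gives 4.2% and compound 1 gives 0%, nothing in the series points to a change beyond the scatter, and the expected step from compound 2 to compound 3 is a number 0.2 percentage points lower from compound 2 to compound 3 (within the scatter), that is, none beyond the scatter. On this basis compound 3 is estimated at 4%, with a range from 0% to 14%.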

Compound 3, a percentage reported as inhibition, at one concentration (the size of the read-out at that concentration, not a potency): 0%
For compound 3 the middle estimate is 4 percentage points above the measured one; measured number inside the range.
By their numbers in this assay, from the lowest: compounds 1, 3 and 2 (each within the scatter of the next).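

In this assay, the series now has its first comparison of compounds that differ in one place: trifluoromethoxy in place of trifluoromethyl on an aromatic carbon gives a number 4.2 percentage points lower from compound 2 to compound 3 (within the scatter). At this position, the two groups cannot be told apart at the one concentration tested, even though trifluoromethoxy brings an oxygen and a hydrogen-bond acceptor into the structure. No measurement available here bears on this result.

As far as these compounds go, whether an amine, a carboxylic acid or a longer alkyl chain at this position would give a read-out beyond the scatter remains open. Also open, from the compounds shown here alone, is whether this exchange would stay within the scatter on a compound with a clearly higher read-out, since compound 2 and compound 3 both sit close to the bottom of the scale.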